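Fluorophenyl for methylphenyl: carrying one step onto a second core

This account rests on a few compounds, and the source may have more. Where it says the series, first, only, none or still open, it means among the compounds named here.

Three rhodanine-type acids have been measured in a functional assay on Raji cells (Homo sapiens) for cytotoxicity, read by MTT assay, with a stated time of 48 h; a higher number here means a weaker inhibitor, a lower number a stronger inhibitor. Compound 1 `Cc1ccc(Cn2c(/C=C3\SC(=S)N(CC(=O)O)C3=O)nc3cc(Cl)ccc32)cc1` gives 20900 nM. Compound 3 `O=C(O)CN1C(=O)/C(=C/c2nc3cc(Cl)ccc3n2Cc2ccccc2F)SC1=S`, which differs from it by 2-fluorophenyl in place of 4-methylphenyl on a saturated chain carbon bound to an aromatic nitrogen, gives 2780 nM; the step from compound 1 to compound 3 is a 7.5-fold lower number from compound 1 to compound 3 (0.88 log units; beyond the scatter). Compound 2 `Cc1ccc(Cn2c(/C=C3\SC(=S)N(CC(=O)O)C3=O)nc3ccc(Cl)cc32)cc1` gives 2790 nM, a number that lies within the scatter of that of compound 3. The two cores of compound 1 and compound 2 hold the same atoms joined differently, and the difference between the two cores is not broken down here.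

Compound 4 `O=C(O)CN1C(=O)/C(=C/c2nc3ccc(Cl)cc3n2Cc2ccccc2F)SC1=S` is not yet measured. It differs from compound 2 by 2-fluorophenyl in place of 4-methylphenyl on a saturated chain carbon bound to an aromatic nitrogen, the same change seen between compound 1 and compound 3. Because compound 2 already sits at 2790 nM, and the two cores are not compared in detail, the writer expects a smaller step than a 7.5-fold lower number from compound 1 to compound 3 (0.88 log units; beyond the scatter): for compound 4 an estimated step of a 3.1-fold lower number from compound 2 to compound 4 (0.49 log units; beyond the scatter) in this assay. The estimated value for compound 4 is 900 nM, expected between 250 nM and 3000 nM.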

Compound 4, half-maximal inhibitory concentration: 8870 nM
For compound 4 the middle estimate is 9.9-fold (0.99 log units) below the measured one, outside the stated range (above it).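

On the core of compound 2, this assay records a 3.2-fold higher number from compound 2 to compound 4 (0.50 log units; beyond the scatter), so 2-fluorophenyl in place of 4-methylphenyl moves the number the opposite way from its effect on the core of compound 1. Set beside the earlier step, the new one differs from it in both direction and size: the same change on two cores in this assay, a 7.5-fold lower number (0.88 log units; beyond the scatter) from compound 1 to compound 3 and a 3.2-fold higher number (0.50 log units; beyond the scatter) from compound 2 to compound 4, 24-fold (1.38 log units) apart, beyond the scatter of two such steps This shows that, across these two pairs, the step measured on one core did not carry over to the other, but it does not show what in the two cores produces the difference, and one pair per core gives no general rule for the series.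

The compounds shown leave open how an unsubstituted benzyl or a 4-methoxybenzyl group would behave on the two cores, and so whether the opposite steps are particular to 2-fluorobenzyl. They also leave open whether the same split would appear with a bromine in place of the chlorine, or with an amide in place of the carboxylic acid.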